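Phenethyl on the carbonyl carbon: a toxicity question

The source may hold more compounds than are shown below. What is called first, only, known or untested is meant among the compounds shown, and "the series" means these compounds.

Measured in a toxicity assay on THP-1 cells (Homo sapiens) for inhibition (a lower number here means that less compound is tolerated, a higher number that more compound is tolerated), so far:
- Compound 1 `CCCC(=O)Nc1ncc(-c2ccc(OC)cc2)n1C` reads > 100000 nM (a limit)
- Compound 2 `COc1ccc(-c2cnc(NC(=O)c3cnc[nH]3)n2C)cc1` reads > 100000 nM (a limit)
- Compound 3 `Cc1cccc(C(=O)Nc2ncc(-c3ccccc3)n2C)c1` reads > 50000 nM (a limit)

None of these three readings is a plain number. The set holds only the limit of > 100000 nM in this assay, at which 2 of the 3 values shown sit, and the limit of > 50000 nM in this assay, at which 1 of the 3 values shown sits (no exact value among them). Compound 2 therefore has no exact place. Its reading of > 100000 nM is a limit, and the same is true of the other two compounds.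

The next compound is compound 4 `COc1ccc(-c2cnc(NC(=O)CCc3ccccc3)n2C)cc1`, which has not been measured yet. It keeps the core of compound 2, but phenethyl takes the place of 1H-imidazol-5-yl on a carbonyl carbon (phenethyl in place of 1H-imidazol-5-yl on a carbonyl carbon).

For the measured compounds named here, the one measured step at this place is a step that the two limits leave unreadable from compound 1 to compound 2 and it offers no size to carry over. The expectation rests instead on the three compounds with different groups on the carbonyl carbon, none of which gave an exact value.

The step expected is an at least 1.2-fold lower number from compound 2 to compound 4 (0.09 log units; that floor lies within the scatter) in this assay, with a slight lean to lower numbers and nothing firmly beyond the scatter. Compound 4 is estimated at 80000 nM (expected range 25000 nM to 100000 nM).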

Compound 4, half-maximal cytotoxic concentration: > 100000 nM
Compound 4: a limit, no number (the forecaster's own chance of this, stated with the estimate: 70%); middle value at least 1.2-fold (0.09 log units) away from the limit.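

In this assay compound 4 gives > 100000 nM, which is a limit and not a number. For the compounds shown here, the steps to compound 4 from compound 1 and from compound 2 cannot be read, and this result yields no new step. The compounds shown leave open whether the different groups on the carbonyl carbon change the half-maximal cytotoxic concentration at all.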